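Amide partner variation in a sulfonamide series: compound 4

The source may hold more compounds than are shown below. What is called first, only, known or untested is meant among the compounds shown, and "the series" means these compounds.

Compound 1 `COc1ccc(Cl)cc1N(CC(=O)Nc1cccc2ccccc12)S(=O)(=O)c1ccccc1`: 17400 nM in a functional assay on SH-SY5Y cells (Homo sapiens), read by MTT assay, with a stated time of 24 h; a lower number here means that less compound is needed, a higher number that more compound is needed for the effect
Compound 2 `COc1ccc(NC(=O)CN(c2cc(Cl)ccc2OC)S(=O)(=O)c2ccccc2)cc1OC`: > 20000 nM in this assay
Compound 3 `COc1ccc(Cl)cc1N(CC(=O)N1CCCCC1)S(=O)(=O)c1ccccc1`: 14500 nM in this assay

The value of compound 2 is a limit of this assay, (the limit of > 20000 nM in this assay, at which 1 of the 3 values shown sits). Compound 3 and compound 1 lie within the scatter of each other, as the step of a 1.2-fold lower number from compound 1 to compound 3 (0.08 log units; within the scatter) shows, and the step of an at least 1.3-fold lower number from compound 2 to compound 3 (0.13 log units; that floor lies within the scatter) also stays within the scatter. Compound 4 `COc1ccc(CNC(=O)CN(c2cc(Cl)ccc2OC)S(=O)(=O)c2ccccc2)cc1` differs from compound 3 by (4-methoxybenzyl)amino in place of piperidin-1-yl on a carbonyl carbon. The two measured exchanges at this carbonyl carbon both left the number in this assay unchanged beyond the scatter, so no step beyond the scatter is expected here either. Compound 4 is accordingly estimated at 16000 nM, between 7000 nM and 40000 nM, an expected step of a 1.1-fold higher number from compound 3 to compound 4 (0.04 log units; within the scatter).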

Compound 4, half-maximal effective concentration: > 20000 nM
Compound 4 gave a limit, no number (the forecaster's own chance of this, stated with the estimate: 30%); at least 1.2-fold (0.09 log units) between middle value and limit.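

In this assay compound 4 gives > 20000 nM, which is a limit and not a number. Putting (4-methoxybenzyl)amino in place of piperidin-1-yl on this carbonyl carbon gives an at least 1.3-fold higher number from compound 3 to compound 4 (0.13 log units; that floor lies within the scatter), and putting 4-methoxybenzyl in place of naphthalen-1-yl on the amide-type nitrogen gives an at least 1.1-fold higher number from compound 1 to compound 4 (0.06 log units; that floor lies within the scatter), so neither floor yet shows a step beyond the scatter. The step between compound 2 and compound 4 cannot be read, and limits now make up a larger share of the values: the limit of > 20000 nM in this assay, at which 2 of the 4 values shown sit.

On these data alone, whether any partner at this carbonyl carbon moves the number beyond the scatter stays open. A morpholine ring or a carboxylic acid on the partner would probe the position further.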